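Acetyl to cyclohexylcarbonyl on compound 1

The source may report more compounds than this note shows. Statements on the series, on what has been measured and on what is new or still open speak of the compounds shown alone.

Values so far in a physicochemical assay for lipophilicity, read by HPLC, measured as chromatographic lipophilicity, at pH 7.4; a lower number here means a more polar compound, a higher number a more lipophilic compound
- compound 1 `CC(=O)N1CCC(C(=O)N2N=CCC2c2ccccc2)CC1` gives 2.5
- compound 2 `CC(C)(C)C(=O)N1N=CCC1c1cccc(F)c1` gives 5.9
- compound 3 `CC(=O)N1CCC(C(=O)N2N=CC[C@H]2c2ccccc2)CC1` gives 2.5

In this assay compound 1 stands at 2.5 and is level with compound 3, while compound 2 at 5.9 lies far above both. The next compound to read is compound 4 `O=C(C1CCCCC1)N1CCC(C(=O)N2N=CCC2c2ccccc2)CC1` with the change cyclohexyl in place of methyl on a carbonyl carbon in which cyclohexyl takes the place of methyl on a carbonyl carbon. For the measured compounds named here, the only measured single-place step is no change at the digits printed from compound 1 to compound 3 (within the scatter) and it concerns the fact that one of compounds 1 and 3 is drawn with a defined configuration and the other without, at the place where they differ alone, so it gives no size for this change. Going by the values given here, no measured step alters the group on this carbonyl. The expectation therefore rests on the change itself, which brings in carbon only and no hydrogen-bond donors or acceptors, and on compound 2 at 5.9 as a sign of how high the series can reach. The expected step of a number 1.90 log units higher from compound 1 to compound 4 (beyond the scatter) is upward and beyond the scatter. Compound 4 is estimated at 4.4 in this assay with an expected range from 3.6 to 5.2 for the measurement.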

Compound 4, distribution coefficient: 5.4
Compound 4: middle estimate off by 1.00 log units, on the low side, outside the stated range (above it).
By their numbers in this assay, from the lowest: compounds 1 and 3 (each within the scatter of the next); then compound 4; then compound 2.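

In this assay, cyclohexyl in place of methyl on a carbonyl carbon reads as a number 2.90 log units higher from compound 1 to compound 4 (beyond the scatter), the first measured size for any change of the group on this carbonyl. The position is therefore not silent in this assay: a carbon-only replacement, with no hydrogen-bond donors or acceptors on either side, moves the number well beyond the scatter. Nothing on record accounts for the size of this step.

From the compounds shown here alone, with a single step at this position, it remains open whether the rise follows the carbon count or depends on the ring itself, a question that a longer chain, a phenyl ring or a cyclohexyl ring carrying an amine on the same carbonyl would address. Also open, going by these compounds, is whether a defined configuration leaves compound 4 unchanged, as it does for compound 1.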